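The source may hold more compounds than are shown below. What is called first, only, known or untested is meant among the compounds shown, and "the series" means these compounds.

Three compounds share one core and differ only in the group on an aromatic carbon of a five-membered aromatic ring with three nitrogens. Compound 3 `COc1nc2ccc(Br)cc2cc1C(c1ccccc1)n1cc(-c2ccccc2F)nn1` carries a 2-fluorophenyl there, and in an ADME assay on PANC-1 cells (Homo sapiens) for cytotoxicity, read by sulforhodamine B assay, with a stated time of 48 h, tested at 10 uM (a higher number here means more inhibition at the concentration tested (going by the name of the read-out), a lower number less inhibition), compound 3 gives 14.7%, the highest of the three numbers, although its distance to each of the others lies within the scatter. Compound 1 `CCCCCCc1cn(C(c2ccccc2)c2cc3cc(Br)ccc3nc2OC)nn1` carries a hexyl and in this assay compound 1 gives 6.08%. Compound 2 `CCCCc1cn(C(c2ccccc2)c2cc3cc(Br)ccc3nc2OC)nn1` carries a butyl and in this assay compound 2 gives 5.46%.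

Compound 4 `CCCCCCCCc1cn(C(c2ccccc2)c2cc3cc(Br)ccc3nc2OC)nn1` is not yet measured. Its difference from compound 3 is octyl in place of 2-fluorophenyl on an aromatic carbon. Among the compounds with values here, two measured steps bear on this: a number 8.6 percentage points higher from compound 1 to compound 3 (within the scatter) and a number 9.2 percentage points higher from compound 2 to compound 3 (within the scatter). A third step, a number 0.6 percentage points lower from compound 1 to compound 2 (within the scatter), shows that lengthening or shortening the chain barely moved the number. Replacing the 2-fluorophenyl by a longer chain is therefore expected to return the number to the level of compounds 1 and 2, a step estimated as a number 7.7 percentage points lower from compound 3 to compound 4 (within the scatter), still within the scatter. Compound 4 is expected to give about 7%, within a range from 0% to 18%.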

Compound 4, a percentage reported as inhibition, at one concentration (the size of the read-out at that concentration, not a potency): 12.1%
Compound 4: middle estimate off by 5.1 percentage points, on the low side; measured number inside the range.
By their numbers in this assay, from the lowest: compounds 2, 1, 4 and 3 (each within the scatter of the next).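

Replacing the 2-fluorophenyl, with its six-membered aromatic ring, by octyl, which has no ring, gives a number 2.6 percentage points lower from compound 3 to compound 4 (within the scatter), so an open chain on this aromatic carbon stays within the scatter of an aryl group. Extending the chain also leaves the number within the scatter, with a number 6.6 percentage points higher from compound 2 to compound 4 (within the scatter) and a number 6 percentage points higher from compound 1 to compound 4 (within the scatter), so butyl, hexyl and octyl cannot be told apart here, and no step among the four compounds goes beyond the scatter. Nothing available gives a reason for these numbers.

The compounds shown leave open whether any group at this position can move the number beyond the scatter, for example a chain ending in an amine or a carboxylic acid. A plain phenyl would show whether the fluorine matters at all.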